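Aryl Variation on a Cyanopyridone Core: Toward a Chlorophenyl Analogue

The compounds below may be only part of what the source reports. "The series", "measured", "known", "first", "only" and "open" are said of these compounds alone.

Measured so far in a functional assay for inhibition, tested at 60 ug/mL; on this read-out higher numbers stand for a stronger effect at the one concentration tested and lower numbers for a weaker effect:
Compound 1, `Cc1cc(O)c(C(C)C)cc1-c1cc(-c2cccs2)c(C#N)c(=O)[nH]1`: compound 1 gives 54.3%
Compound 2, `COc1ccc(-c2cc(-c3cc(C(C)C)c(O)cc3C)[nH]c(=O)c2C#N)c(OC)c1`: compound 2 gives 48.5%
Compound 3, `COc1ccc(-c2cc(-c3cc(C(C)C)c(O)cc3C)[nH]c(=O)c2C#N)cc1OC`: compound 3 gives 52%

The three compounds share one core and differ only in the aryl group attached to it. Their numbers in this assay lie close together: compound 3 sits between the other two, separated from compound 1 by a number 2.3 percentage points lower from compound 1 to compound 3 (within the scatter) and from compound 2 by a number 3.5 percentage points higher from compound 2 to compound 3 (within the scatter), and compounds 1 and 2 are apart by a number 5.8 percentage points lower from compound 1 to compound 2 (within the scatter). None of these steps rises above the scatter, so on the numbers shown the three aryl groups are indistinguishable.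

Compound 4, `Cc1cc(O)c(C(C)C)cc1-c1cc(-c2ccccc2Cl)c(C#N)c(=O)[nH]1`, is the next analogue. The change from compound 3 is 2-chlorophenyl in place of 3,4-dimethoxyphenyl on an aromatic carbon. Among the compounds with values here, the steps that bear on it are exactly those three aryl exchanges, all within the scatter. The account therefore expects no step beyond the scatter from compound 3 to compound 4 in this assay, that is, an expected a number 2 percentage points lower from compound 3 to compound 4 (within the scatter). Compound 4 is estimated to give 50%, with a range from 36% to 64%.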

Compound 4, a percentage reported as inhibition, at one concentration (the size of the read-out at that concentration, not a potency): 26%
Compound 4: the middle estimate sits 24 percentage points above what was measured; the measured number lies below the stated range.
By their numbers in this assay, from the lowest: compound 4; then compounds 2, 3 and 1 (each within the scatter of the next).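

The position opposite the ring nitrogen is not indifferent to its aryl group: in this assay, 2-chlorophenyl stands clearly apart from each of the earlier groups (a number 26 percentage points lower from compound 3 to compound 4 (beyond the scatter); a number 22.5 percentage points lower from compound 2 to compound 4 (beyond the scatter); a number 28.3 percentage points lower from compound 1 to compound 4 (beyond the scatter)). The earlier tolerance therefore covers thiophen-2-yl, 2,4-dimethoxyphenyl and 3,4-dimethoxyphenyl, but it does not extend to every aryl group at this position. Nothing measured here accounts for the difference.

From the compounds shown here alone, whether the loss follows the chlorine itself or its place on the phenyl ring remains open, and 3-chlorophenyl, 4-chlorophenyl, 2-methoxyphenyl or unsubstituted phenyl at this position would help separate the two. Going by these compounds, it is also open whether these single-concentration percentages reflect a corresponding difference in potency.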